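This account rests on a few compounds, and the source may have more. Where it says the series, first, only, none or still open, it means among the compounds named here.

Measured compounds in a functional assay, with a stated time of 90 s; a lower number here means a stronger inhibitor, a higher number a weaker inhibitor:
compound 1 `Cc1nc2c3ccccc3ccc2c2nc3c(ccc4ccccc43)c(-c3ccccc3N)c12` gives 125 ug/mL
compound 2 `Cc1nc2c3ccccc3ccc2c2nc3c(ccc4ccccc43)c(-c3ccccc3S)c12` gives 158 ug/mL
compound 3 `Cc1nc2c3ccccc3ccc2c2nc3c(ccc4ccccc43)c(-c3ccc(O)cc3)c12` gives 99 ug/mL

Compound 3 has the lowest of the three numbers in this assay, yet it sits within the scatter of both others: the step of a 1.3-fold lower number from compound 1 to compound 3 (0.10 log units; within the scatter) and the step of a 1.6-fold lower number from compound 2 to compound 3 (0.20 log units; within the scatter) are each too small to rank the compounds. Within the data shown here, the only other measured step, a 1.3-fold higher number from compound 1 to compound 2 (0.10 log units; within the scatter), is likewise within the scatter.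

Compound 4 `Cc1ccc(-c2c3ccc4ccccc4c3nc3c2c(C)nc2c4ccccc4ccc32)cc1` differs from compound 3 in one place: methyl in place of hydroxy on an aromatic carbon. Among the measured compounds shown here, no measured pair in this set exchanges hydroxy for methyl, so nothing bears directly on this change. What the three measured steps do show is that swapping the group on the pendant phenyl ring, whether amino, sulfanyl or 4-hydroxyphenyl, left this assay unmoved beyond its scatter. On that basis compound 4 is expected to stay near compound 3, with the estimated step of a 1.1-fold higher number from compound 3 to compound 4 (0.05 log units; within the scatter) not exceeding the scatter. The expected value for compound 4 in this assay is 110 ug/mL, with a range from 55 ug/mL to 220 ug/mL.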

Compound 4, half-maximal inhibitory concentration: 192 ug/mL
The estimate for compound 4 lay 1.7-fold (0.24 log units) below the measured number; low and high end bracket the measured number.
By their numbers in this assay, from the lowest: compounds 3, 1, 2 and 4 (each within the scatter of the next).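

In this assay, methyl in place of hydroxy on the six-membered aromatic ring, para to a large group, gives a 1.9-fold higher number from compound 3 to compound 4 (0.29 log units; within the scatter). This is the first exchange shown at this place, and losing the hydrogen-bond donor and acceptor counted for hydroxy does not separate the two compounds beyond the scatter. The 4-methylphenyl group of compound 4 is equally unresolved from the two ortho-free comparisons available, with a 1.2-fold higher number from compound 2 to compound 4 (0.08 log units; within the scatter) and a 1.5-fold higher number from compound 1 to compound 4 (0.19 log units; within the scatter), and nothing measured here explains any of these numbers.

The compounds shown leave open whether a carboxylic acid, an amine or a longer alkyl chain at this same place would move the number beyond the scatter. They also leave open what an unsubstituted phenyl ring would give on the shared core.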